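This account rests on a few compounds, and the source may have more. Where it says the series, first, only, none or still open, it means among the compounds named here.

Working notes on the series. Compound 1 `COc1ccc(C2=NN(C3=NC(=O)/C(=C4\C(=O)Nc5ccc(Br)cc54)S3)C(c3ccc(OC)cc3)C2)cc1` and compound 2 `COc1ccc(C2CC(c3ccc4ccccc4c3)=NN2C2=NC(=O)/C(=C3\C(=O)Nc4ccc(Br)cc43)S2)cc1` share one core; compound 3 `COc1ccc(C2=NN(C3=NC(=O)/C(=C4\C(=O)Nc5ccccc54)S3)C(c3ccc(Cl)cc3)C2)cc1` and compound 4 `O=C1N=C(N2N=C(c3ccc4ccccc4c3)CC2c2ccc(Cl)cc2)S/C1=C1/C(=O)Nc2ccccc21` share another, and the difference between the two cores is not broken down here. In a functional assay on cells (Melanoma cell, Homo sapiens) for cytotoxicity, read by sulforhodamine B assay, with a stated time of 48 h (a lower number here means a stronger inhibitor of growth, a higher number a weaker inhibitor of growth), compound 1 gives 410 nM, and compound 2 gives 190 nM. The change naphthalen-2-yl in place of 4-methoxyphenyl on a carbon with a double bond to nitrogen thus produced a 2.2-fold lower number from compound 1 to compound 2 (0.33 log units; beyond the scatter). Compound 3 gives 100000 nM in this assay, far weaker than either of the other two measured compounds.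

Compound 4 carries the same kind of change on the core of compound 3: naphthalen-2-yl in place of 4-methoxyphenyl on a carbon with a double bond to nitrogen. The surroundings are not identical, since in compound 3 the ring atom two ring bonds away bears a 4-chlorophenyl group (7 heavy atoms), whereas in compound 1 it bears a 4-methoxyphenyl group (8 heavy atoms). Going by the values given here, only one earlier instance of this change exists, so the expectation leans on it alone, tempered by the very different level of compound 3. The step from compound 3 to compound 4 in this assay is expected to be a 2.0-fold lower number from compound 3 to compound 4 (0.30 log units; within the scatter), resting on a 2.2-fold lower number from compound 1 to compound 2 (0.33 log units; beyond the scatter). Compound 4 is accordingly estimated at 50000 nM, between 15000 nM and 120000 nM.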

Compound 4, concentration for total growth inhibition: 24700 nM
Beside the measured number, compound 4's estimate is 2.0-fold (0.31 log units) above it; measured number inside the range.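

In this assay naphthalen-2-yl in place of 4-methoxyphenyl gives a 4.0-fold lower number from compound 3 to compound 4 (0.61 log units; beyond the scatter), the same direction as on the core of compound 1, so the change carries over to the second core in direction. The two steps also show no real difference in size: the same change on two cores in this assay, a 2.2-fold lower number (0.33 log units; beyond the scatter) from compound 1 to compound 2 and a 4.0-fold lower number (0.61 log units; beyond the scatter) from compound 3 to compound 4, 1.9-fold (0.27 log units) apart, within the scatter of two such steps. This agreement rests on two cores alone; it does not show that the step would hold on any other core, and it does not explain the difference between the two cores, which is not broken down here.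

Still open, on these data alone, is whether the lower number depends on naphthalen-2-yl itself, or whether another group at this place, such as a cyclohexyl ring or a phenyl ring carrying a dimethylamino group or a carboxylic acid, would give a similar step. Also open, as far as these compounds go, is how the step would change if the ring atom that bears a 4-chlorophenyl group carried a small alkyl chain or a morpholine instead.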